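Cyclopropyl entering the phenyl of compound 2

The source may report more compounds than this note shows. Statements on the series, on what has been measured and on what is new or still open speak of the compounds shown alone.

Measured so far:
compound 1 `COc1cccc(NC(=O)c2nnn(CC3CCN(C(C)=O)CC3)c2N)c1` — > 50100 nM
compound 2 `COc1cccc(NC(=O)c2nnn(Cc3ccccc3)c2N)c1` — > 50100 nM

Both values in a toxicity assay on Vero cells (Chlorocebus sabaeus) for inhibition (a higher number here means that more compound is needed for the effect, a lower number that less compound is needed), are limits of the assay, not numbers. Compound 1 gives only a limit. Compound 2 likewise gives only a limit, so its standing on this assay is known no closer than that limit. Within the data shown here, the one measured step, a step that the two limits leave unreadable from compound 1 to compound 2, cannot be read because of the limit of > 50100 nM in this assay, at which 2 of the 2 values shown sit.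

Compound 3 `COc1cccc(NC(=O)c2nnn(Cc3ccc(C4CC4)cc3)c2N)c1` is the next member. It differs from compound 2 in one place: cyclopropyl in place of hydrogen on an aromatic carbon. Among the measured compounds shown here, the only measured step that bears on this change gives no readable size, so no direction can be taken from it; the two limits simply leave the cyclopropyl-for-hydrogen change unconstrained.

For compound 3 the expected value in this assay is estimated at 50100 nM, between 20000 nM and 100000 nM. The expected step of a number no higher from compound 2 to compound 3 (the limit leaves the size open) is none beyond the scatter, most likely again a limit.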

Compound 3, half-maximal effective concentration: > 50100 nM
Compound 3 ended at the assay's limit (the forecaster's own chance of this, stated with the estimate: 80%); the middle value sits exactly at the limit.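

No new step can be read from compound 3 against compound 2 or compound 1, because each value is a limit and not a number: the limit of > 50100 nM in this assay, at which 3 of the 3 values shown sit.

Still open, as far as these compounds go, is how far apart phenyl, 4-cyclopropylphenyl and 1-acetylpiperidin-4-yl lie in this assay.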